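Swapping the aryl group on a ring amide nitrogen

The source may report more compounds than this note shows. Statements on the series, on what has been measured and on what is new or still open speak of the compounds shown alone.

Of the compounds shown here, three built on a shared core have been measured in a functional assay on SK-BR-3 cells (Homo sapiens) for cytotoxicity, read by sulforhodamine B assay, with a stated time of 48 h; a higher number here means a weaker inhibitor, a lower number a stronger inhibitor. Compound 1 `CO[C@@H]1CC=C2NN(c3cc(Cl)cc(Cl)c3)C(=O)CC[C@]2(c2ccccc2)O1` gives 6350 nM. Compound 2 `CO[C@@H]1CC=C2N(c3ccc(C)cc3)C(=O)C[C@]2(c2ccccc2)O1` gives 1100 nM. Compound 3 `CO[C@@H]1CC=C2N(c3ccccn3)C(=O)C[C@]2(c2ccccc2)O1` gives 1100 nM. Compound 3 and compound 2 are level within the scatter, and together they hold the lowest numbers of the three; compound 1 stands higher, and that gap lies beyond the scatter.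

The next compound, compound 4 `CO[C@@H]1CC=C2N(c3c[nH]c4ccccc34)C(=O)C[C@]2(c2ccccc2)O1`, differs from compound 3 in one place: 1H-indol-3-yl in place of pyridin-2-yl on an amide-type nitrogen in a ring. For the measured compounds named here, the one measured step that bears on this position is the exchange of the aryl group on the same amide nitrogen, no change at the digits printed from compound 2 to compound 3 (within the scatter). That step shows that replacing one aromatic ring by another at this position left the number where it was. Going by the values given here, no measured step covers an aromatic group with a hydrogen-bond donor at this position, so nothing in the data points to a shift in either direction.

The expectation for compound 4 is therefore a step of no change at the digits printed from compound 3 to compound 4 (within the scatter), that is, no change beyond the scatter. Compound 4 is estimated to give 1100 nM in this assay, within a range from 400 nM to 3500 nM.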

Compound 4, half-maximal inhibitory concentration: 2300 nM
For compound 4 the middle estimate is 2.1-fold (0.32 log units) below the measured one; the range from low to high includes it.
By their numbers in this assay, from the lowest: compounds 2 and 3 (each within the scatter of the next); then compound 4; then compound 1.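

Aromatic groups on this amide-type nitrogen are not all interchangeable: in this assay the entry of 1H-indol-3-yl brings a 2.1-fold higher number from compound 3 to compound 4 (0.32 log units; beyond the scatter) and also a 2.1-fold higher number from compound 2 to compound 4 (0.32 log units; beyond the scatter) against two groups, pyridin-2-yl and 4-methylphenyl, that stood level with each other. Because a higher number means a weaker inhibitor here, this exchange of one aromatic group for another moves the result beyond the scatter towards weaker, though only modestly. The change swaps a single six-membered aromatic ring for a five-membered and a six-membered aromatic ring together, while also adding a hydrogen-bond donor and removing a hydrogen-bond acceptor, and nothing available explains the rise or separates these differences.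

The compounds shown leave open whether the second ring or the ring hydrogen matters more, a question that naphthalen-2-yl or 1-methylindol-3-yl on the same nitrogen would address. They also leave open how groups of a different kind would fare at this position, such as a benzyl group, a butyl chain or a phenyl ring carrying a carboxylic acid.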